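Swapping a butenyl chain for a methylcyclopropyl on compound 3

The source may report more compounds than this note shows. Statements on the series, on what has been measured and on what is new or still open speak of the compounds shown alone.

Measured compounds:
compound 1 `CCCCn1c(Cc2cc(OC)c(OC)c(OC)c2)nc2c(N)nc(F)nc21`: 24000 nM
compound 2 `C#CCCn1c(Cc2cc(OC)c(OC)c(OC)c2)nc2c(N)nc(F)nc21`: 25100 nM
compound 3 `CC/C=C/Cn1c(Cc2cc(OC)c(OC)c(OC)c2)nc2c(N)ncnc21`: 46800 nM

All three values come from a functional assay on MCF7 cells (Homo sapiens) for antiproliferative activity; on this read-out higher numbers stand for weaker inhibition and lower numbers for stronger inhibition. The number for compound 3 lies within the scatter of the numbers for compound 1 and compound 2, so the three compounds cannot be told apart on this assay.

Compound 4 `COc1cc(Cc2nc3c(N)ncnc3n2CC2(C)CC2)cc(OC)c1OC` has not yet been measured. It arises from compound 3 by 1-methylcyclopropyl in place of but-1-en-1-yl on a saturated chain carbon bound to an aromatic nitrogen. Going by the values given here, the one measured step that touches the chain on the aromatic nitrogen is a 1.0-fold higher number from compound 1 to compound 2 (0.02 log units; within the scatter), which left the number unchanged within the scatter. Among the compounds with values here, that step sits two bonds further out than the present change and swaps an open chain for another open chain, so it is only a loose guide; no measured step puts one three-membered non-aromatic ring in this place.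

Within the data shown here, with the only related evidence showing no shift, the expectation for compound 4 is a number close to that of compound 3, with a 1.0-fold lower number from compound 3 to compound 4 (0.02 log units; within the scatter) lying within the scatter and no direction favoured. The estimate for compound 4 in this assay is 45000 nM, with a range from 15000 nM to 140000 nM.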

Compound 4, half-maximal inhibitory concentration: 112000 nM
Compound 4: the middle estimate sits 2.5-fold (0.40 log units) below what was measured, and the stated range covers the measured number.
By their numbers in this assay, from the lowest: compounds 1, 2 and 3 (each within the scatter of the next); then compound 4.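

In this assay, going by these compounds alone, the change at this saturated chain carbon bound to an aromatic nitrogen moves the number a 2.4-fold higher number from compound 3 to compound 4 (0.38 log units; beyond the scatter) and so gives the first modest step beyond the scatter on this chain, towards weaker inhibition. The leaving but-1-en-1-yl and the entering 1-methylcyclopropyl each hold 4 heavy atoms, all carbon, and neither has a hydrogen-bond donor or acceptor, so at this place the number can shift even when the atoms stay the same and only the way they are joined differs. Nothing available explains why this rearrangement gives weaker inhibition.

Within the data shown here, with only this one pair, it remains open whether the step follows from the three-membered ring itself, from the methyl on that ring or from the loss of the double bond. A plain cyclopropyl or a saturated butyl group in the same place on the shared core of compound 3 would help to separate these possibilities, while an amine on the chain would show how this position responds to a group that is not made of carbon alone.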